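A few compounds are considered here, and "the series" means these few. Any claim that something is new, unique, unknown or untested is made for them only; others in the source may bear on it.

Among the compounds with values here, in a physicochemical assay for lipophilicity (on this read-out lower numbers stand for lower lipophilicity and higher numbers for higher lipophilicity), two compounds built on a shared core have numbers so far. Compound 1 (`CCCCCCS(=O)(=O)c1ccc(O)c(C(=O)Nc2ccc(Br)cc2)c1`) gives 3.2, and compound 2 (`CCCCS(=O)(=O)c1ccc(O)c(C(=O)Nc2ccc(Br)cc2)c1`) gives 2.48, the lower of the two. Compound 3 (`CCCCCCCCCCS(=O)(=O)c1ccc(O)c(C(=O)Nc2ccc(Br)cc2)c1`) has not yet been measured. It departs from compound 2 by hexyl in place of hydrogen on a saturated chain carbon, four bonds along the chain from a sulfonyl sulfur. The same difference can also be read as ethyl to octyl.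

Within the data shown here, only one measured step bears on this change, and it sits at the same carbon, with hydrogen in place of ethyl. Read in reverse, a number 0.72 log units lower from compound 1 to compound 2 (beyond the scatter) points to a higher number for a longer chain. Hexyl is a longer chain than ethyl, so a clearly larger upward step is expected here. One step cannot show whether the numbers keep rising evenly as a chain grows, so the range has to stay wide. The expected change is a number 2.12 log units higher from compound 2 to compound 3 (beyond the scatter). The estimated value for compound 3 is 4.6, with an expected range of 3.9 to 5.4.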

Compound 3, distribution coefficient: 5.36
For compound 3 the middle estimate is 0.76 log units below the measured one, within the range that was stated.
By their numbers in this assay, from the lowest: compound 2; then compound 1; then compound 3.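

In this assay, the rise seen earlier carries on well beyond compound 1, with a number 2.88 log units higher from compound 2 to compound 3 (beyond the scatter) for hexyl in place of hydrogen on a saturated chain carbon, four bonds along the chain from a sulfonyl sulfur. The step of a number 2.16 log units higher from compound 1 to compound 3 (beyond the scatter) adds butyl in place of hydrogen on a saturated chain carbon, six bonds along the chain from a sulfonyl sulfur, and shows that the number has not levelled off at the chain length of compound 1. Across these three compounds, a longer chain goes with a higher number and none goes against this, but no supporting data are available to explain the size of these steps.

These three straight chains cannot show whether a still longer chain would keep raising the number or whether the rise would flatten out. They also leave open what a branched chain of similar size would give, or a chain ending in a carboxylic acid or an amine, since all the chains shown consist only of saturated carbons and hydrogens.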